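Series notes: shortening the chain from compound 3 to compound 4

The source may report more compounds than this note shows. Statements on the series, on what has been measured and on what is new or still open speak of the compounds shown alone.

The series is followed in a functional assay on the whole organism (strain Swiss) with Mus musculus as the target, in the maximal electroshock model, with a stated time of 0.5 h, at a dose of 100 mg/kg by the intraperitoneal route; a lower number here means a weaker effect, a higher number a stronger effect of the compound at the dose given. Compound 1 `COc1cccc(N2CCN(C(=O)C(C)N3C(=O)CCC3=O)CC2)c1` gives 0% in this assay, and compound 2 `CC(C(=O)N1CCN(c2cccc(F)c2)CC1)N1C(=O)CCC1=O` gives 0%; the step of no change at the digits printed from compound 1 to compound 2 (within the scatter). Compound 3 `CCC(C(=O)N1CCN(c2cccc(Cl)c2)CC1)N1C(=O)CCC1=O` gives 50%, the highest of the three numbers, standing beyond the scatter above both compound 1 and compound 2 by the same margin.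

Compound 4 `CC(C(=O)N1CCN(c2cccc(Cl)c2)CC1)N1C(=O)CCC1=O` is not yet measured. The change from compound 3 to compound 4 is hydrogen in place of methyl on a saturated chain carbon, two bonds along the chain from an amide-type nitrogen in a ring and a carbonyl carbon. For the measured compounds named here, no measured step covers this change; the only measured step concerns the aromatic substituent, so the size of this step cannot be read from the recorded work. What can be said is that compound 1 gives 0% and compound 2 gives 0% with the shorter chain, while compound 3 with the longer chain gives 50%, though the aromatic substituent differs as well.

The step of a number 30 percentage points lower from compound 3 to compound 4 (beyond the scatter) is expected to be downward, since compound 1 gives 0% with the shorter chain. Compound 4 is estimated at 20%, with a range from 0% to 50%.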

Compound 4, a percentage reported as activity, at one dose (the size of the read-out at that dose, not a potency): 75%
Compound 4: middle estimate off by 55 percentage points, on the low side, and the stated range ends below it.
By their numbers in this assay, from the lowest: compounds 1 and 2 (each within the scatter of the next); then compound 3; then compound 4.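

In this assay, hydrogen in place of methyl on a saturated chain carbon, two bonds along the chain from an amide-type nitrogen in a ring and a carbonyl carbon, gives a number 25 percentage points higher from compound 3 to compound 4 (beyond the scatter) and shows that ethyl is not needed at this position for the effect to appear, at least with chloro on the aromatic carbon. With the methyl held constant, chloro in place of fluoro gives a number 75 percentage points higher from compound 2 to compound 4 (beyond the scatter) and chloro in place of methoxy gives a number 75 percentage points higher from compound 1 to compound 4 (beyond the scatter), so the aromatic substituent carries much larger steps here than the chain change does. Nothing recorded for this series bears on the reason for these steps.

Still open, going by these compounds, is whether a propyl group at the chain position, or no alkyl group there at all, would continue or reverse this step. Also open, on these data alone, is how bromo or trifluoromethyl would compare with chloro on the aromatic carbon.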